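Aromatic substitution on the enone series: nitro step

The compounds below may be only part of what the source reports. "The series", "measured", "known", "first", "only" and "open" are said of these compounds alone.

Within the data shown here, compound 1 `CC(=O)OC/C(=C\c1ccccc1)C(=O)c1ccccc1` is the parent of the two measured members. In a functional assay on T47D cells (Homo sapiens) for inhibition, read by sulforhodamine B assay, with a stated time of 48 h (on this read-out lower numbers stand for stronger inhibition of growth and higher numbers for weaker inhibition of growth), compound 1 gives 16000 nM. Compound 2 `CC(=O)OC/C(=C\c1ccccc1Br)C(=O)c1ccccc1` carries a bromo on the aromatic carbon; in this assay compound 2 gives 17000 nM, and the step of a 1.1-fold higher number from compound 1 to compound 2 (0.03 log units; within the scatter) shows both numbers falling together, so neither stands apart from the other on the numbers shown.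

The next member, compound 3 `CC(=O)OC/C(=C\c1ccc([N+](=O)[O-])cc1)C(=O)c1ccccc1`, differs from compound 1 by nitro in place of hydrogen on an aromatic carbon. Among the measured compounds shown here, the only measured step that bears on it is the bromo step, a 1.1-fold higher number from compound 1 to compound 2 (0.03 log units; within the scatter), which left this assay unchanged beyond the scatter. For the measured compounds named here, no step with a nitro, or with any group on the position named here, is measured, so the bromo step is the sole guide. On that basis the step from compound 1 to compound 3 in this assay is expected to be small, no change at the digits printed from compound 1 to compound 3 (within the scatter), with no direction beyond the scatter claimed. Compound 3 is therefore estimated at 16000 nM in this assay, with a range from 6000 nM to 45000 nM.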

Compound 3, concentration for 50% growth inhibition: 16000 nM
Compound 3: the middle estimate sits on the measured number at the digits printed; the measured number falls inside the stated range.
By their numbers in this assay, from the lowest: compounds 1, 3 and 2 (each within the scatter of the next).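

With nitro in place of hydrogen, para to a large group on the aromatic ring, this assay gives no change at the digits printed from compound 1 to compound 3 (within the scatter) and so shows no change that can be read at this position. Taken with a 1.1-fold higher number from compound 1 to compound 2 (0.03 log units; within the scatter) as the other step from the parent, two different replacements of an aromatic hydrogen on compound 1 now stay within the scatter, and the nitro result adds that a group larger than a single bromo atom can sit on this ring without moving the number beyond it. Nothing accompanying the result bears on why the number holds.

As far as these compounds go, whether an amine, a carboxylic acid or a methoxy group at the same place would also stay within the scatter remains open, so the flat result holds for nitro alone at this position. Also open, from the compounds shown here alone, is whether a change elsewhere on the core of compound 1, such as a longer chain in place of the acetyl group or a substituent on the aromatic ring attached to the carbonyl, would shift the number beyond the scatter.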